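Changing the tail on the shared core, measured in rats

The compounds below may be only part of what the source reports. "The series", "measured", "known", "first", "only" and "open" are said of these compounds alone.

Three compounds were measured in a functional assay on the whole organism with Rattus norvegicus as the target, at a dose of 100 mg/kg; a lower number here means less inhibition, a higher number more inhibition at the dose given (going by the name of the read-out):
compound 1, `C/N=C(\S)NCCCCCn1nc(-c2ccccc2)ccc1=O`, gives 68.9%
compound 2, `CC/N=C(\S)NCCCCn1nc(-c2ccccc2)ccc1=O`, gives 67.7%
compound 3, `CN(C)/C(=N/CCCn1nc(-c2ccccc2)ccc1=O)NC#N`, gives 72.2%

Among these three numbers compound 1 stands second highest. Its nearest neighbour is compound 2, with a number 1.2 percentage points lower from compound 1 to compound 2 (within the scatter), and its furthest is compound 3, with a number 3.3 percentage points higher from compound 1 to compound 3 (within the scatter); both steps lie within the scatter, so the three compounds cannot be told apart in this assay.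

Compound 4, `CC/N=C(/NC#N)NCCCCCn1nc(-c2ccccc2)ccc1=O`, is not yet measured. It differs from compound 1 in one place: a group of 7 heavy atoms (4 carbon, 3 nitrogen; no ring) in place of a group of 4 heavy atoms (2 carbon, 1 nitrogen, 1 sulfur; no ring), on an amine nitrogen.

Within the data shown here, two measured steps bear on this change. Each of them also replaces a sulfur-containing tail with a nitrogen-containing tail that carries a nitrile: a number 3.3 percentage points higher from compound 1 to compound 3 (within the scatter) and a number 4.5 percentage points higher from compound 2 to compound 3 (within the scatter). Neither reached beyond the scatter. For compound 4 a step of about a number 1.1 percentage points higher from compound 1 to compound 4 (within the scatter) is therefore expected, that is, no change beyond the scatter. Compound 4 is estimated at 70%, with a range from 60% to 80%.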

Compound 4, a percentage reported as inhibition, in the whole organism at one dose (the size of the read-out at that dose, not a potency): 48.2%
Estimate against measurement, compound 4: 21.8 percentage points above, and the stated range ends above it.
By their numbers in this assay, from the lowest: compound 4; then compounds 2, 1 and 3 (each within the scatter of the next).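

Placed on the amine nitrogen of this pentyl-chain compound, the nitrile-bearing group gives a number 20.7 percentage points lower from compound 1 to compound 4 (beyond the scatter) in this assay and is the first change in this set to reach beyond the scatter. A nitrile on the tail therefore does not leave the number unchanged in every setting, since compound 3 also carries one and the step of a number 3.3 percentage points higher from compound 1 to compound 3 (within the scatter) shows no such fall. Nothing measured here accounts for the lower inhibition of compound 4.

The compounds shown leave open whether the fall follows the nitrile itself or the larger group as a whole, since both differ from the group that leaves. A urea, with a carbonyl in place of the sulfur on the same chain, could help separate these possibilities, and a shorter chain carrying the tail of compound 4 would test whether chain length matters.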